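Fluoro in place of hydrogen across two cores

This account rests on a few compounds, and the source may have more. Where it says the series, first, only, none or still open, it means among the compounds named here.

Measured so far in a functional assay on K562 cells (Homo sapiens) for cytotoxicity, read by trypan blue exclusion, with a stated time of 96 h; on this read-out higher numbers stand for weaker inhibition and lower numbers for stronger inhibition:

compound 1 `COc1ccc(/C=C/S(=O)(=O)Nc2ccc(OC)c(F)c2)cc1` gives 1000 nM
compound 2 `COc1ccc(/C=C/S(=O)(=O)Nc2ccc(OC)cc2)cc1` gives 5000 nM
compound 3 `COc1ccc(NS(=O)(=O)/C=C/c2c(OC)cc(OC)cc2OC)cc1` gives 75 nM

Compound 2 and compound 1 share one core and differ only by fluoro in place of hydrogen on an aromatic carbon. That single change gave a 5.0-fold lower number from compound 2 to compound 1 (0.70 log units; beyond the scatter).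

Compound 3 carries a different core; the difference between the two cores is not broken down here. In this assay compound 3 stands with the lowest number of the three, and its steps to compound 1 and to compound 2 are both beyond the scatter.

Compound 4 `COc1cc(OC)c(/C=C/S(=O)(=O)Nc2ccc(OC)c(F)c2)c(OC)c1` has not yet been measured. It differs from compound 3 by fluoro in place of hydrogen on an aromatic carbon. The place is described in the same words as for the change from compound 2 to compound 1, so this is the same change applied to the second core.

For compound 4 the expected step is a 3.0-fold lower number from compound 3 to compound 4 (0.48 log units; beyond the scatter), resting on the step from compound 2 to compound 1, which gave a 5.0-fold lower number from compound 2 to compound 1 (0.70 log units; beyond the scatter), and on the value of compound 3, which gave 75 nM. The step is assumed to carry over only in part, since it has been seen once and on another core. The estimate for compound 4 in this assay is 25 nM, with a range from 8 nM to 75 nM.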

Compound 4, half-maximal inhibitory concentration: 75 nM
Compound 4: middle estimate off by 3.0-fold (0.48 log units), on the low side; measured number inside the range.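

In this assay, the change from 4-methoxyphenyl to 3-fluoro-4-methoxyphenyl did not repeat its earlier result on the second core, giving no change at the digits printed from compound 3 to compound 4 (within the scatter). Set side by side, the two steps differ, so the change does not carry over as a fixed step between these cores: the same change on two cores in this assay, a 5.0-fold lower number (0.70 log units; beyond the scatter) from compound 2 to compound 1 and no change at the digits printed (within the scatter) from compound 3 to compound 4, 5.0-fold (0.70 log units) apart, beyond the scatter of two such steps. For the compounds shown here, this shows only that a step seen on one core can fail to appear on another; with a single pair on each core, it does not show which feature of the cores goes with the difference, nor how the change would behave on any further core.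

Open, as far as these compounds go, is whether an amine, a hydroxy group or a chloro group on that aromatic carbon, ortho to a methoxy group, would follow compound 1 or compound 4 in its step from the matching parent. Also open, from the compounds shown here alone, is whether the difference between the two steps would hold in a read-out other than this cytotoxicity measurement on K562 cells.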